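A few compounds are considered here, and "the series" means these few. Any claim that something is new, unique, unknown or untested is made for them only; others in the source may bear on it.

Compound 1, with the structure `O=C(O)Cc1sc(C(c2ccccc2)c2ccccc2)nc1-c1ccc(F)cc1`, was tested in an in vitro assay on HEK385-7 cells for displacement of a labelled ligand from prostaglandin D2 receptor 2 (Homo sapiens) (on this read-out lower numbers stand for stronger inhibition and higher numbers for weaker inhibition), where compound 1 gives 8.7 nM. Compound 2, `O=C(O)Cc1sc(C(c2ccccc2)c2ccccc2)nc1-c1ccc(F)c(F)c1`, carries one more fluorine on the ring that hangs from the shared core; the change is fluoro in place of hydrogen on an aromatic carbon. In this assay compound 2 gives 4.1 nM, and the step is a 2.1-fold lower number from compound 1 to compound 2 (0.33 log units; beyond the scatter).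

Compound 3, `O=C(O)Cc1sc(C(c2ccc(F)cc2)c2ccc(F)cc2)nc1-c1cccc(F)c1`, has a different core from compound 1, and that difference is not broken down here. In this assay compound 3 gives 1.4 nM, the lowest number of the three measured compounds.

Compound 4, `O=C(O)Cc1sc(C(c2ccc(F)cc2)c2ccc(F)cc2)nc1-c1cc(F)cc(F)c1`, has not yet been measured. It differs from compound 3 by fluoro in place of hydrogen on an aromatic carbon. Within the data shown here, this is the same kind of change as the one from compound 1 to compound 2, though the surroundings differ: in compound 2 the new fluorine sits ortho to a fluoro group, in compound 4 meta to a fluoro group, while both sit meta to a large group. Since one added fluorine gave the step of a 2.1-fold lower number from compound 1 to compound 2 (0.33 log units; beyond the scatter), the step to compound 4 is expected to be a 1.4-fold lower number from compound 3 to compound 4 (0.15 log units; within the scatter). Compound 4 is therefore estimated at 1 nM, likely between 0.4 nM and 2.8 nM.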

Compound 4, half-maximal inhibitory concentration: 35 nM
For compound 4 the middle estimate is 35-fold (1.54 log units) below the measured one; the measured number lies above the stated range.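

In this assay, the added fluorine now gives a 25-fold higher number from compound 3 to compound 4 (1.40 log units; beyond the scatter), so the step weakens inhibition rather than strengthening it. Set beside the earlier step, the same change does not carry over between these two cores in either size or direction: the same change on two cores in this assay, a 2.1-fold lower number (0.33 log units; beyond the scatter) from compound 1 to compound 2 and a 25-fold higher number (1.40 log units; beyond the scatter) from compound 3 to compound 4, 53-fold (1.72 log units) apart, beyond the scatter of two such steps This shows that a gain from one added fluorine on one core is no safe guide to its effect on another, but it does not show why: the two pairs differ both in the rest of the core and in where the new fluorine sits relative to the fluoro group already on the ring, and one pair per core cannot separate these differences.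

The compounds shown leave open whether the 3,5-difluorophenyl group would also weaken inhibition on the core of compound 1, which would help show whether the rest of the core matters. They also leave open whether a chlorine or a methyl group in the same place would follow the fluorine.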